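A new ring on the shared core

This account rests on a few compounds, and the source may have more. Where it says the series, first, only, none or still open, it means among the compounds named here.

Compound 3 `CCN1C(=O)N(c2ccc(C(=O)NC)cc2)C(=O)N(c2ccccc2)c2cc(C(F)(F)F)ccc21` gives 31000 nM in an ADME assay on C8166 cells (Homo sapiens) for cytotoxicity; on this read-out higher numbers stand for lower toxicity in this test and lower numbers for higher toxicity in this test. Compound 2 `CCN1C(=O)N(c2ccc(O)cc2)C(=O)N(c2ccccc2)c2cc(C(F)(F)F)ccc21`, with hydroxy in place of methylcarbamoyl on an aromatic carbon, gives 35000 nM, so the two stand level. Compound 1 `CCN1C(=O)N(c2ccc(OC)cc2)C(=O)N(c2ccccc2)c2cc(C(F)(F)F)ccc21`, the methoxy member of the series, reads > 16000 nM, which is a limit of the assay and not a number. This leaves its two steps, a step that the limit leaves unreadable from compound 1 to compound 2 and a step that the limit leaves unreadable from compound 1 to compound 3, without a usable size.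

The structural change to compound 4 `CCN1C(=O)N(c2cc(C)c(O)c(Cl)c2)C(=O)N(c2ccccc2)c2cc(C(F)(F)F)ccc21` is 3-chloro-4-hydroxy-5-methylphenyl in place of 4-(methylcarbamoyl)phenyl on an amide-type nitrogen in a ring. In words, 3-chloro-4-hydroxy-5-methylphenyl replaces 4-(methylcarbamoyl)phenyl on an amide-type nitrogen in a ring. For the measured compounds named here, compound 4 carries a hydroxy, as compound 2 does, but no measured step covers the chlorine or the methyl that come with it.

Going by the values given here, the only readable step is a 1.1-fold lower number from compound 2 to compound 3 (0.05 log units; within the scatter), and it shows that exchanging hydroxy and methylcarbamoyl on this ring hardly moved this assay. That single small step is thin evidence, so no large shift is expected, and the direction remains uncertain. The estimated change is a 1.2-fold lower number from compound 3 to compound 4 (0.09 log units; within the scatter). For compound 4 the expected value is 25000 nM, with an estimated range from 9000 nM to 60000 nM.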

Compound 4, half-maximal cytotoxic concentration: > 10000 nM
Compound 4 gave a limit, no number (the forecaster's own chance of this, stated with the estimate: 20%); the middle value lies beyond the limit too.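

In this assay compound 4 gives > 10000 nM, which is a limit of the assay and not a number, so its steps from compound 1, compound 2 and compound 3 cannot be read. The compounds shown leave open whether the 3-chloro-4-hydroxy-5-methylphenyl group of compound 4 shifts this read-out at all, and in which direction.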